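Swapping the Side Ring on a Shared Core

A few compounds are considered here, and "the series" means these few. Any claim that something is new, unique, unknown or untested is made for them only; others in the source may bear on it.

Three compounds have been measured in an assay for inhibition of Catechol O-methyltransferase (Rattus norvegicus), read by fluorescence and spectrophotometry; on this read-out higher numbers stand for weaker inhibition and lower numbers for stronger inhibition:

Compound 1, `CC(=O)N1N=C(c2cc(O)c(O)c([N+](=O)[O-])c2)CC1c1cccs1`: 210 nM
Compound 2, `CC(=O)N1N=C(c2cc(O)c(O)c([N+](=O)[O-])c2)CC1c1ccc(C#N)cc1`: 48 nM
Compound 3, `CC(=O)N1N=C(c2cc(O)c(O)c([N+](=O)[O-])c2)CC1c1cccc(O)c1`: 75 nM

Compound 3 stands second highest of these three numbers. Its nearest neighbour is compound 2, and that gap, a 1.6-fold higher number from compound 2 to compound 3 (0.19 log units; within the scatter), is within the usual scatter, so the two cannot be told apart. Its furthest neighbour is compound 1, and that gap, a 2.8-fold lower number from compound 1 to compound 3 (0.45 log units; beyond the scatter), is beyond the scatter.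

The next compound, compound 4, is `CC(=O)N1N=C(c2cc(O)c(O)c([N+](=O)[O-])c2)CC1c1ccco1`. The change from compound 3 is furan-2-yl in place of 3-hydroxyphenyl on a saturated ring carbon.

Going by the values given here, two measured steps bear on this. Both start from compound 1, which carries thiophen-2-yl, a five-membered aromatic ring, at the same saturated ring carbon: a 4.4-fold lower number from compound 1 to compound 2 (0.64 log units; beyond the scatter) and a 2.8-fold lower number from compound 1 to compound 3 (0.45 log units; beyond the scatter). In each case moving to a six-membered ring of carbon only gave a modestly lower number. Compound 4 returns to a five-membered aromatic ring with one hetero atom, so the expectation is a modest move back up toward the number of compound 1, that is a 2.0-fold higher number from compound 3 to compound 4 (0.30 log units; within the scatter). On this basis compound 4 is estimated at 150 nM, with a range from 60 nM to 400 nM.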

Compound 4, half-maximal inhibitory concentration: 180 nM
The estimate for compound 4 lay 1.2-fold (0.08 log units) below the measured number; measured number inside the range.
By their numbers in this assay, from the lowest: compounds 2 and 3 (each within the scatter of the next); then compounds 4 and 1 (each within the scatter of the next).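

In this assay, swapping one five-membered aromatic ring with a single hetero atom for another at this saturated ring carbon leaves the number where it was, with furan-2-yl and thiophen-2-yl indistinguishable (a 1.2-fold lower number from compound 1 to compound 4 (0.07 log units; within the scatter)). Furan-2-yl also stands clearly apart from both six-membered rings of carbon only (a 2.4-fold higher number from compound 3 to compound 4 (0.38 log units; beyond the scatter); a 3.8-fold higher number from compound 2 to compound 4 (0.57 log units; beyond the scatter)), so in these four compounds the split between five-membered and six-membered rings now rests on two examples on each side, and none goes against it. No measurement at hand says what lies behind this split.

The hydrogen-bond donor that leaves with 3-hydroxyphenyl cannot be judged alone, since the ring size changes in the same step, and a plain phenyl ring would show whether the six-membered ring alone goes with the lower numbers or whether the hydroxyl and nitrile groups are needed. Also open, going by these compounds, is whether the split survives with a pyridinyl ring, which puts nitrogen into a six-membered ring, with a saturated cyclohexyl ring, or with an amine or a carboxylic acid on the side ring.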